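Working notes: benzyl to 3-cyanophenyl on the shared core

This account rests on a few compounds, and the source may have more. Where it says the series, first, only, none or still open, it means among the compounds named here.

Measured so far in a functional assay on T98G cells (Homo sapiens) for inhibition, read by MTT assay, with a stated time of 72 h; a higher number here means a weaker inhibitor, a lower number a stronger inhibitor:
- compound 1 `CC1(C)CC(NC(=S)Nc2cccc(C#N)c2)c2cc(Br)ccc2O1` at 9000 nM
- compound 2 `CC1(C)CC(NC(=S)NCc2ccccc2)c2cc(Cl)ccc2O1` at 99000 nM

Of these two, compound 2 stands highest with 99000 nM and is the weaker inhibitor, while compound 1 has 9000 nM and the gap between them lies beyond the scatter. The two compounds differ in more than one place, on the core as well as on the nitrogen, so the data do not assign this gap to either change.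

Compound 3 `CC1(C)CC(NC(=S)Nc2cccc(C#N)c2)c2cc(Cl)ccc2O1` keeps the core of compound 2 and takes 3-cyanophenyl in place of benzyl on an amide-type nitrogen as the next step to examine. The expectation rests on compound 1, which carries the same 3-cyanophenyl group and gives 9000 nM in this assay as its only reference point. A move to a lower number, beyond the scatter, is expected, with an estimated size of a 9.0-fold lower number from compound 2 to compound 3 (0.95 log units; beyond the scatter) on this thin basis. For compound 3 the estimated value is 11000 nM with an expected range from 4000 nM to 30000 nM in this assay when measured.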

Compound 3, half-maximal inhibitory concentration: 10000 nM
Compound 3: the middle estimate sits 1.1-fold (0.04 log units) above what was measured; low and high end bracket the measured number.
By their numbers in this assay, from the lowest: compounds 1 and 3 (each within the scatter of the next); then compound 2.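

Going by these compounds alone, on the core of compound 2, 3-cyanophenyl in place of benzyl on an amide-type nitrogen gives a 9.9-fold lower number from compound 2 to compound 3 (1.00 log units; beyond the scatter) in this assay, the first reading of this position with nothing else on the molecule changed. Within the data shown here, with 3-cyanophenyl kept on that nitrogen, chloro in place of bromo on an aromatic carbon gives a 1.1-fold higher number from compound 1 to compound 3 (0.05 log units; within the scatter) and so lies within the scatter, which means this pair does not separate the two halogens in this assay and the nitrogen substituent is the only one of the two changes with a readable effect here. Nothing at hand bears on the reason for either step.

The step on the nitrogen changes two things at once, the benzyl linking carbon and the nitrile, so the compounds shown do not tell which of them goes with the lower number; a plain phenyl or a 3-cyanobenzyl on the same nitrogen would part the two. Going by these compounds, whether the nitrile itself can give way to a carboxylic acid, an amine or a longer chain also stays open.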